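This account rests on a few compounds, and the source may have more. Where it says the series, first, only, none or still open, it means among the compounds named here.

The measured compounds and their values:

Compound 1, `Cn1c(-c2ccc(NC(=O)CSc3nc4ccccc4o3)cc2)nc(-c2ccccc2)c1-c1ccccc1`: 11 ug/mL
Compound 2, `Cc1ccc2oc(SCC(=O)Nc3ccc(-c4nc(-c5ccccc5)c(-c5ccccc5)n4C)cc3)nc2c1`: 22.4 ug/mL
Compound 3, `Cn1c(-c2ccc(NC(=O)CN3CCN(Cc4ccccc4)CC3)cc2)nc(-c2ccccc2)c1-c1ccccc1`: 65.5 ug/mL

All three were tested in a functional assay on HT-29 cells (Homo sapiens) for cytotoxicity, read by MTT assay, with a stated time of 24 h; a lower number here means a stronger inhibitor, a higher number a weaker inhibitor. Compound 2 differs from compound 1 by methyl in place of hydrogen on an aromatic carbon, and this change gave a 2.0-fold higher number from compound 1 to compound 2 (0.31 log units; beyond the scatter). Compound 3 shares the core of the others but carries a different side chain; the difference between the two cores is not broken down here, and compound 3 stands highest of the three numbers in this assay.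

The unmeasured compound 4, `Cc1ccc(CN2CCN(CC(=O)Nc3ccc(-c4nc(-c5ccccc5)c(-c5ccccc5)n4C)cc3)CC2)cc1`, differs from compound 3 by methyl in place of hydrogen on an aromatic carbon. Among the compounds with values here, this is the same kind of change as the one from compound 1 to compound 2, but not the same: in compound 2 the methyl sits on a ring that is part of a fused or bridged system of two rings, meta and para to a fused ring, whereas in compound 4 it sits on a six-membered aromatic ring of carbon only, para to a large group.

For compound 4 a step of a 1.5-fold higher number from compound 3 to compound 4 (0.18 log units; within the scatter) is expected, resting on the step from compound 1 to compound 2, a 2.0-fold higher number from compound 1 to compound 2 (0.31 log units; beyond the scatter), with added uncertainty because the surroundings differ. Compound 4 is therefore estimated at 100 ug/mL, between 45 ug/mL and 220 ug/mL.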

Compound 4, half-maximal inhibitory concentration: 62 ug/mL
Estimate against measurement, compound 4: 1.6-fold (0.21 log units) above, and the stated range covers the measured number.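

In this assay, within the data shown here, the change from benzyl to 4-methylbenzyl gave a 1.1-fold lower number from compound 3 to compound 4 (0.02 log units; within the scatter), so on this side chain the added methyl produced no step that stands out from the scatter. Set beside the earlier step on the other side chain, the new step does not differ from it by more than repeated measurements allow: the same change on two cores in this assay, a 2.0-fold higher number (0.31 log units; beyond the scatter) from compound 1 to compound 2 and a 1.1-fold lower number (0.02 log units; within the scatter) from compound 3 to compound 4, 2.2-fold (0.33 log units) apart, within the scatter of two such steps. Among these compounds, this gives no ground for saying that the change behaves differently on the two cores, but it does not show that the change carries over unaltered, as there is only one pair for each core and the methyl sits on a different ring in each.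

The compounds shown leave open how a chloro, a methoxy or an amine would read in place of the methyl on the six-membered aromatic ring of carbon only, and whether a longer chain such as ethyl would read like methyl. They also leave open whether the methyl would read the same at another place on that ring.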